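Methyl for hydrogen on the aryl ether of compound 3

The source may report more compounds than this note shows. Statements on the series, on what has been measured and on what is new or still open speak of the compounds shown alone.

The measured compounds:
Compound 1, `CCc1ccccc1N(Cc1nnc(Cc2ccc(OC)cc2)o1)S(=O)(=O)c1ccc(C)cc1`: 126 nM; 126 nM (2 entries)
Compound 2, `CCOc1ccc(Cc2nnc(CN(c3ccccc3CC)S(=O)(=O)c3ccc(C)cc3)o2)cc1`: 126 nM
Compound 3, `COc1ccc(Cc2nnc(CN(c3cccc(Cl)c3C)S(=O)(=O)c3ccc(C)cc3)o2)cc1`: 6.31 nM

In an assay on CHO cells for displacement of a labelled ligand from prostaglandin E2 receptor EP1 subtype (Homo sapiens) (on this read-out lower numbers stand for stronger inhibition and higher numbers for weaker inhibition), compound 3 gives 6.31 nM, the lowest of the two single numbers, with compound 2 standing a long way higher at 126 nM, beyond the scatter. Compound 1 carries two entries rather than one number and gives 126 nM; 126 nM (2 entries) in this assay.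

Compound 4, `CCOc1ccc(Cc2nnc(CN(c3cccc(Cl)c3C)S(=O)(=O)c3ccc(C)cc3)o2)cc1`, has not been measured. It differs from compound 3 by methyl in place of hydrogen on a saturated chain carbon bound to an oxygen on an aromatic ring. The same exchange, methoxy to ethoxy, separates compound 1 from compound 2, and those two compounds show the same value in this assay, so no step beyond the scatter is listed or suggested for them. Within the data shown here, no direct step is given for the pair at hand. Compound 4 is therefore expected to stay close to compound 3, with a step from compound 3 to compound 4 of a 1.0-fold higher number from compound 3 to compound 4 (0.01 log units; within the scatter) in this assay, within the scatter. Compound 4 is estimated at 6.5 nM, in the range 3 nM to 14 nM.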

Compound 4, half-maximal inhibitory concentration: 3.98 nM
The estimate for compound 4 lay 1.6-fold (0.21 log units) above the measured number; the range from low to high includes it.
By their numbers in this assay, from the lowest: compounds 4 and 3 (each within the scatter of the next); then compound 2.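

With 3-chloro-2-methylphenyl on the sulfonamide nitrogen, the exchange of methoxy for ethoxy in this assay gives a 1.6-fold lower number from compound 3 to compound 4 (0.20 log units; within the scatter) and so changes nothing that can be told apart, just as compound 1 and compound 2 show matching values with 2-ethylphenyl in that place. With ethoxy held constant, the exchange of 2-ethylphenyl for 3-chloro-2-methylphenyl gives a 32-fold lower number from compound 2 to compound 4 (1.50 log units; beyond the scatter) and so places a large difference at the group on the sulfonamide nitrogen, while the extra methyl on the ether leaves the value where it was. Nothing at hand explains either result.

The compounds shown leave open whether a longer chain such as propoxy, or an amine or a carboxylic acid carried on the ether chain, would keep the value. Also open, as far as these compounds go, is how the chloro and methyl groups of 3-chloro-2-methylphenyl each contribute to the large step.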